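The source may report more compounds than this note shows. Statements on the series, on what has been measured and on what is new or still open speak of the compounds shown alone.

Compound 1, `Cc1ccc(NN=C2CCC(C)n3c2ncc(C(=O)O)c3=O)cc1C`, gives in a functional assay on the whole organism with Rattus norvegicus as the target (on this read-out higher numbers stand for an effect only at larger amounts of compound and lower numbers for an effect already at smaller amounts), a value that is a limit of the assay, > 100 umol/kg.
Compound 2, `CC1CCC(=NNc2ccc(Cl)cc2Cl)c2ncc(C(=O)O)c(=O)n21`, gives in this assay a limit, > 100 umol/kg.
Compound 3, `CC1CCC(=NNc2cc(Cl)ccc2O)c2ncc(C(=O)O)c(=O)n21`, gives in this assay a limit, > 100 umol/kg.

For compound 3 only this limit is known, and the other two compounds share it: all three sit at the limit of > 100 umol/kg in this assay, at which 3 of the 3 values shown sit. The steps among them, a step that the two limits leave unreadable from compound 1 to compound 2, a step that the two limits leave unreadable from compound 1 to compound 3 and a step that the two limits leave unreadable from compound 2 to compound 3, are not readable in size, so none of them shows whether exchanging the group on the amine nitrogen moves the dose at all.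

Compound 4, `CNN=C1CCC(C)n2c1ncc(C(=O)O)c2=O`, has not yet been measured in this assay. It differs from compound 3 in one place: methyl in place of 5-chloro-2-hydroxyphenyl on an amine nitrogen. The measured steps that bear on this change are the two ending at compound 3, a step that the two limits leave unreadable from compound 1 to compound 3 and a step that the two limits leave unreadable from compound 2 to compound 3; both exchange one group for another on the same amine nitrogen, and both are unreadable because every value involved is a limit (the limit of > 100 umol/kg in this assay, at which 3 of the 3 values shown sit). No readable step in either direction exists in the measured set, so no step beyond the scatter can be anticipated, nor can one be ruled out.

Compound 4 is therefore expected to give 150 umol/kg in this assay, within a range from 50 umol/kg to 500 umol/kg, most likely again as a limit. The step this estimate means is expected to be a step that the limit leaves unreadable from compound 3 to compound 4.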

Compound 4, dose for 50% inhibition: > 100 umol/kg
Compound 4: no number, only a limit; the forecaster's own chance of this, stated with the estimate: 80%; the middle value is on the limit's open side.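

In this assay compound 4 gives a limit, > 100 umol/kg. Its steps from compound 1, compound 2 and compound 3 cannot be read in size, so this result yields no new step: the limit of > 100 umol/kg in this assay, at which 4 of the 4 values shown sit.

The compounds shown leave open whether exchanging the group on the amine nitrogen moves the dose at all.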